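The compounds below may be only part of what the source reports. "The series", "measured", "known", "first", "only" and "open" are said of these compounds alone.

Compound 1 `CC(C)=CCOc1cccc(Nc2nccs2)c1` gives 23000 nM in a functional assay on MT2 cells (Homo sapiens) for cytotoxicity, read by MTT assay; on this read-out lower numbers stand for higher toxicity in this test and higher numbers for lower toxicity in this test. Compound 2 `CC(C)=CCOc1cc(Nc2nccs2)ccc1C` carries the change methyl in place of hydrogen on an aromatic carbon relative to compound 1, and in this assay compound 2 gives 17000 nM; the step of a 1.4-fold lower number from compound 1 to compound 2 (0.13 log units; within the scatter). Compound 3 `CC(C)=CCOc1cc(Nc2ncccn2)ccc1Cl` rests on a different core, and the difference between the cores of compound 1 and compound 3 is not broken down here. In this assay compound 3 gives 2500 nM, the lowest of the three numbers, and its gaps to compound 2 and to compound 1 both lie beyond the scatter. Compound 4 `CC(C)=CCOc1cc(Nc2nccc(C)n2)ccc1Cl` has not been measured; it differs from compound 3 by methyl in place of hydrogen on an aromatic carbon. This is the same kind of change as from compound 1 to compound 2, but the surroundings differ: in compound 2 the methyl sits on a six-membered aromatic ring of carbon only, ortho to a (3-methylbut-2-en-1-yl)oxy group and para to a (1,3-thiazol-2-yl)amino group, whereas in compound 4 it sits on a six-membered aromatic ring with 2 nitrogen, next to the ring nitrogen and meta to a large group. Because the earlier step of a 1.4-fold lower number from compound 1 to compound 2 (0.13 log units; within the scatter) stayed within the scatter, the expected step in this assay is a 1.3-fold lower number from compound 3 to compound 4 (0.10 log units; within the scatter). Compound 4 is accordingly estimated at 2000 nM, between 800 nM and 6000 nM.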

Compound 4, half-maximal cytotoxic concentration: < 200 nM
Compound 4 was reported as a limit; the forecaster's own chance of this, stated with the estimate: 5%; middle value at least 10-fold (1.00 log units) from the limit.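

The new step reads an at least 12-fold lower number from compound 3 to compound 4 (1.09 log units; beyond the scatter), so in this assay methyl in place of hydrogen on an aromatic carbon did not carry over in size from one core to the other: the same change on two cores in this assay, a 1.4-fold lower number (0.13 log units; within the scatter) from compound 1 to compound 2 and an at least 12-fold lower number (1.09 log units; beyond the scatter) from compound 3 to compound 4, at least 9.2-fold (0.96 log units) apart, beyond the scatter of two such steps

Compound 4 is reported only as a limit of the assay, < 200 nM, and not as a number, so the size of its step has a bound but no fixed value: the limit of < 200 nM in this assay, at which 1 of the 4 values shown sits.

The methyl sits on a six-membered aromatic ring of carbon only in compound 2 and on a six-membered aromatic ring with 2 nitrogen in compound 4, and two pairs cannot show whether this or some other difference between the cores accounts for the gap, or how the change would behave on any further core.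

The compounds shown leave open whether an ethyl group or an amine in place of the methyl of the 4-methylpyrimidin-2-yl group would give a step of like size in this assay. They also leave open how far the number for compound 4 lies past its limit.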